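A Methyl Group Added to the Core of Compound 1

The source may report more compounds than this note shows. Statements on the series, on what has been measured and on what is new or still open speak of the compounds shown alone.

Compound 1 `Cc1ccc(NC(=O)c2cccc(C(F)(F)F)c2)cc1OC1CCN(C(=O)c2cccnc2)CC1`, > 10000 nM; compound 2 `C=CC(=O)N1CCC(Oc2cc(NC(=O)c3cccc(C(F)(F)F)c3)ccc2C)CC1`, > 10000 nM.

In an ADME assay on BaF3 cells (Mus musculus) for antiproliferative activity (a lower number here means a stronger inhibitor of growth, a higher number a weaker inhibitor of growth), compound 1 gives > 10000 nM, which is a limit of the assay and not a number. Compound 2 likewise reaches only a limit at > 10000 nM. The step that the two limits leave unreadable from compound 1 to compound 2 is therefore not readable. Both results sit at the limit of > 10000 nM in this assay, at which 2 of the 2 values shown sit. Compound 3 `Cc1ccc(NC(=O)c2ccc(C)c(C(F)(F)F)c2)cc1OC1CCN(C(=O)c2cccnc2)CC1` differs from compound 1 by methyl in place of hydrogen on an aromatic carbon. Going by the values given here, no measured step bears on this change, and compound 1 itself stands only at a limit. Compound 3 is therefore expected to stay at the limit too, with an expected step that the limit leaves unreadable from compound 1 to compound 3 that carries little information. Compound 3 is estimated at 15000 nM, in a range from 3000 nM to 60000 nM.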

Compound 3, concentration for 50% growth inhibition: 5470 nM
The estimate for compound 3 lay 2.7-fold (0.44 log units) above the measured number, and the stated range covers the measured number.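

In this assay, methyl in place of hydrogen, turning 3-(trifluoromethyl)phenyl into 4-methyl-3-(trifluoromethyl)phenyl, gives an at least 1.8-fold lower number from compound 1 to compound 3 (0.26 log units; that floor lies within the scatter). Going by these compounds alone, compound 3 thus carries the first readable number, though the true size of the step remains unknown. Compound 1 and compound 2 stand only at a limit of the assay: the limit of > 10000 nM in this assay, at which 2 of the 3 values shown sit.

Still open, going by these compounds, is whether an ethyl chain, a chlorine atom or an amine at this place would lower the number as well. Also open, on these data alone, is whether the same methyl group would bring compound 2 off its limit.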